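The source may report more compounds than this note shows. Statements on the series, on what has been measured and on what is new or still open speak of the compounds shown alone.

Measured compounds in a functional assay on PC-3 cells (Homo sapiens) for cytotoxicity, read by MTT assay, with a stated time of 72 h; a higher number here means a weaker inhibitor, a lower number a stronger inhibitor:
- compound 1 `COc1ccc(OC)c(/C=C/C(=O)Nc2cc3c(Nc4ccc(F)c(Cl)c4)ncnc3cc2O[C@H]2CCOC2)c1`: 8730 nM
- compound 2 `COc1cc(/C=C/C(=O)Nc2cc3c(Nc4ccc(F)c(Cl)c4)ncnc3cc2OC)cc(OC)c1`: "not active" (no number reported)
- compound 3 `COc1cc(/C=C/C(=O)Nc2cc3c(Nc4ccc(F)c(Cl)c4)ncnc3cc2O[C@H]2CCOC2)cc(OC)c1`: 25600 nM

Compound 2 has no single number in this assay; it stands only as an inactive entry. Compound 4 `COc1ccc(/C=C/C(=O)Nc2cc3c(Nc4ccc(F)c(Cl)c4)ncnc3cc2OC)cc1` is the unmeasured analogue. Relative to compound 2 the change is 4-methoxyphenyl in place of 3,5-dimethoxyphenyl on a double-bonded chain carbon bound to a double-bonded chain carbon.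

Among the compounds with values here, the one measured step that bears on the aryl group at this place is a 2.9-fold higher number from compound 1 to compound 3 (0.47 log units; beyond the scatter), where the 3,5-dimethoxyphenyl compound is the weaker of the pair. Compound 2, which also carries 3,5-dimethoxyphenyl, is the inactive one, so 4-methoxyphenyl in place of 3,5-dimethoxyphenyl is expected to move this assay toward a lower number, though compound 2 gives no starting value from which to size the step, and the shared core of compound 4 differs from that of compound 1 and compound 3. The expected result for compound 4 is 30000 nM, in a range of 8000 nM to 100000 nM, with a real chance that only a limit is reported.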

Compound 4, half-maximal inhibitory concentration: "not active" (no number reported)
The entry for compound 4 holds no number; no gap can be computed for the estimate.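

In this assay compound 2 and compound 4 are both entered as "not active" with no number, and no new step can be read between them. No evidence shown bears on this result.

The compounds shown leave open whether 4-methoxyphenyl in place of 3,5-dimethoxyphenyl shifts potency at all on this shared core.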